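The source may report more compounds than this note shows. Statements on the series, on what has been measured and on what is new or still open speak of the compounds shown alone.

Three measured compounds frame the step. Compound 1 `COc1ncc(-c2ccc3c(c2)N(c2ccc(C)cc2)C(=O)CO3)cc1NS(=O)(=O)c1ccc(F)cc1` gives 28300 nM in a functional assay on HepG2 cells (Homo sapiens) for antiproliferative activity, read by MTT assay, with a stated time of 72 h; a lower number here means a stronger inhibitor, a higher number a weaker inhibitor. Compound 2 `O=C1COc2ccc(-c3ccc(O)cc3)cc2N1` gives 38200 nM in this assay. Compound 3 `O=C1COc2ccc(-c3cccc(NS(=O)(=O)c4ccc(F)cc4)c3)cc2N1c1ccc(Cl)cc1` gives 27800 nM in this assay. Compound 3 holds the lowest of the three numbers, yet its gap to compound 1 and its gap to compound 2 both lie within the scatter, so no order among the three can be read from them.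

Compound 4 `COc1cccc(N2C(=O)COc3ccc(-c4cccc(NS(=O)(=O)c5ccc(F)cc5)c4)cc32)c1` has not yet been measured. It differs from compound 3 in one place: 3-methoxyphenyl in place of 4-chlorophenyl on an amide-type nitrogen in a ring. Among the compounds with values here, no pair of measured compounds differing in a single place is available, so the data give no direct measure of how an exchange on that amide-type nitrogen moves the read-out. Within the data shown here, what the three known numbers do show is that they sit close together, whatever group occupies that nitrogen in compound 1, compound 2 or compound 3.

On that basis the step from compound 3 to compound 4 in this assay is expected to be a 1.1-fold higher number from compound 3 to compound 4 (0.03 log units; within the scatter), none beyond the scatter, because compound 3 itself gives 27800 nM and nothing in the set points elsewhere. Compound 4 is therefore estimated at 30000 nM, with a range from 12000 nM to 75000 nM.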

Compound 4, half-maximal inhibitory concentration: > 40000 nM
Compound 4 was reported as a limit; the forecaster's own chance of this, stated with the estimate: 10%; middle value at least 1.3-fold (0.12 log units) from the limit.
By their numbers in this assay, from the lowest: compounds 3, 1 and 2 (each within the scatter of the next). At a limit, above all of these: compound 4.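

Compounds 3 and 4 form the only pair shown that differs in a single place, so the exchange on the amide-type nitrogen can now be read directly. In this assay, 3-methoxyphenyl in place of 4-chlorophenyl gives an at least 1.4-fold higher number from compound 3 to compound 4 (0.15 log units; that floor lies within the scatter). The value of compound 4 is a limit of the assay and not a number, so the step has a floor but no measured size: the limit of > 40000 nM in this assay, at which 1 of the 4 values shown sits. The pair therefore shows that this exchange, which brings in a hydrogen-bond acceptor that 4-chlorophenyl lacks, gave no lower number in this assay, although its floor does not clear the scatter and a rise cannot be firmly claimed.

Going by these compounds, how far compound 4 lies past its limit stays open, and with it the true size of the step. Also open, on these data alone, is how 4-methoxyphenyl or 3-chlorophenyl on that nitrogen would read, which would separate the identity of the group from its place on the phenyl ring, and how an amine or a carboxylic acid carried there on a longer chain would move the number.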